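The source may hold more compounds than are shown below. What is called first, only, known or untested is meant among the compounds shown, and "the series" means these compounds.

Working notes on the series. Compound 1 `CC(C)NC1=NS(=O)(=O)c2cc(F)ccc2N1` and compound 2 `CCC(C)NC1=NS(=O)(=O)c2cc(F)ccc2N1` share one core; compound 3 `CNC1=NS(=O)(=O)c2cc(Cl)ccc2N1` carries another, and the difference between the two cores is not broken down here. In a functional assay (aorta) with Rattus norvegicus as the target (on this read-out lower numbers stand for an effect already at smaller amounts and higher numbers for an effect only at larger amounts of compound), compound 1 gives 43.1 uM, compound 2 gives 39.2 uM and compound 3 gives 142 uM. Compound 3 thus stands with the highest number of the three, beyond the scatter against both others, and is the least potent so far.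

Among the compounds with values here, the one single-point step measured is methyl in place of hydrogen on a saturated chain carbon, two bonds along the chain from an amine nitrogen, which gave a 1.1-fold lower number from compound 1 to compound 2 (0.04 log units; within the scatter).

Compound 4 `CCNC1=NS(=O)(=O)c2cc(Cl)ccc2N1` is still to be measured in this assay. It derives from compound 3 by methyl in place of hydrogen on a saturated chain carbon bound to an amine nitrogen. Within the data shown here, this is the same kind of change as the one from compound 1 to compound 2, but not the same one: there the methyl entered two bonds along the chain from an amine nitrogen, here it enters on a saturated chain carbon bound to an amine nitrogen, so methylamino becomes ethylamino.

For the expectation, the nearest guide is the earlier step, because a 1.1-fold lower number from compound 1 to compound 2 (0.04 log units; within the scatter) showed that adding a methyl on the chain hardly moved the number. The estimated step is a 1.4-fold lower number from compound 3 to compound 4 (0.15 log units; within the scatter), expected to be modest. Compound 4 is therefore expected near 100 uM. For compound 4 the expected range runs from 40 uM to 250 uM.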

Compound 4, concentration for half-maximal effect: 39.9 uM
Compound 4: middle estimate off by 2.5-fold (0.40 log units), on the high side; the whole stated range lies above it.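

In this assay, methyl in place of hydrogen on a saturated chain carbon bound to an amine nitrogen gives a 3.6-fold lower number from compound 3 to compound 4 (0.55 log units; beyond the scatter), so the change from methylamino to ethylamino lowers the number clearly, and the size of the earlier methyl step does not carry over to this one: the same change on two cores in this assay, a 1.1-fold lower number (0.04 log units; within the scatter) from compound 1 to compound 2 and a 3.6-fold lower number (0.55 log units; beyond the scatter) from compound 3 to compound 4, 3.2-fold (0.51 log units) apart, beyond the scatter of two such steps This shows that, within this series, adding a methyl to the amine chain cannot be assumed to have the same size of effect on one core as on the other. Within the data shown here, it does not show that the core alone sets the size of the step, since the two steps also differ in where the methyl enters, and each core offers only a single step.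

Open, going by these compounds, is how methylamino and ethylamino behave on the core of compound 1, and how isopropylamino behaves on the core of compound 3, which would separate the role of the core from that of the place of the methyl. Also open, on these data alone, is whether a longer chain, such as butylamino, continues the step from compound 3 to compound 4 on the core of compound 3.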